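Replacing a Hydrazine Amino Group with Cyclopentyl

This account rests on a few compounds, and the source may have more. Where it says the series, first, only, none or still open, it means among the compounds named here.

Measured so far:
compound 2 `NNc1cc(-c2c(-c3ccc(F)cc3)nn3c(NC4CCCC4)cccc23)ccn1`: 40000 nM
compound 1 `Fc1ccc(-c2nn3c(NC4CCCC4)cccc3c2-c2ccsc2)cc1`: "not determined" (no result reported)

Among the measured compounds shown here, in an ADME assay on Vero cells (Chlorocebus sabaeus) for cytotoxicity (on this read-out higher numbers stand for lower toxicity in this test and lower numbers for higher toxicity in this test), compound 2 gives 40000 nM, the only number this set holds, since in this assay compound 1 gives "not determined" (no result reported). Compound 3 `Fc1ccc(-c2nn3c(NC4CCCC4)cccc3c2-c2ccnc(NC3CCCC3)c2)cc1` differs from compound 2 by one change: cyclopentyl in place of amino on a nitrogen on an aromatic ring. For the measured compounds named here, no step between measured compounds is known, so there is no measured basis for a direction. The expectation is a step from compound 2 to compound 3 of a 1.3-fold lower number from compound 2 to compound 3 (0.12 log units; within the scatter), within the scatter. Compound 3 is therefore estimated at 30000 nM, with a range from 10000 nM to 80000 nM.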

Compound 3, half-maximal cytotoxic concentration: > 40000 nM
Compound 3 gave a limit, no number; the forecaster's own chance of this, stated with the estimate: 30%; middle value at least 1.3-fold (0.12 log units) away from the limit.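

Putting cyclopentyl in place of amino on a nitrogen on an aromatic ring gives, in this assay, a number no lower from compound 2 to compound 3 (the limit leaves the size open). This position therefore carries the five-carbon ring, with the hydrogen-bond donor and acceptor of the amino group gone, without any drop in the number. How far the number rises cannot be told, because the result for compound 3 is a limit: the limit of > 40000 nM in this assay, at which 1 of the 3 values shown sits.

The compounds shown leave open how a smaller group such as methyl, or a longer chain such as butyl, on this nitrogen would read in this assay.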